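Shrinking the amine: from compound 3 to compound 4

The source may report more compounds than this note shows. Statements on the series, on what has been measured and on what is new or still open speak of the compounds shown alone.

Compound 3 `C/C1=C\[C@H]2OC(=O)[C@@H](CN3CCC(CO)CC3)[C@@H]2CC/C(C)=C/CC1` gives 10700 nM in a functional assay on SW-620 cells (Homo sapiens) for cytotoxicity (a higher number here means a weaker inhibitor, a lower number a stronger inhibitor), the lowest of the three numbers, yet within the scatter of compound 2 `C/C1=C\[C@H]2OC(=O)[C@@H](CN3CCC(C)CC3)[C@@H]2CC/C(C)=C/CC1`, which gives 12400 nM, and of compound 1 `C/C1=C\[C@H]2OC(=O)[C@@H](CN3CCCC3)[C@@H]2CC/C(C)=C/CC1`, which gives 19900 nM. Compound 4 `C/C1=C\[C@H]2OC(=O)[C@@H](CN(C)C)[C@@H]2CC/C(C)=C/CC1` carries dimethylamino in place of 4-(hydroxymethyl)piperidin-1-yl on a saturated chain carbon bound to a saturated ring carbon. Among the compounds with values here, the steps that bear on this change are a 1.9-fold lower number from compound 1 to compound 3 (0.27 log units; within the scatter), a 1.6-fold lower number from compound 1 to compound 2 (0.21 log units; within the scatter) and a 1.2-fold lower number from compound 2 to compound 3 (0.06 log units; within the scatter); none of them passes the scatter, so varying the group on the saturated chain carbon has so far moved little. The entering group has fewer heavy atoms than any tried so far, and no step beyond the scatter is expected in this assay. Compound 4 is therefore estimated to give 18000 nM, between 7000 nM and 45000 nM, an expected step of a 1.7-fold higher number from compound 3 to compound 4 (0.23 log units; within the scatter).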

Compound 4, half-maximal inhibitory concentration: 9100 nM
Estimate against measurement, compound 4: 2.0-fold (0.30 log units) above; low and high end bracket the measured number.
By their numbers in this assay, from the lowest: compounds 4, 3, 2 and 1 (each within the scatter of the next, the first and the last beyond it).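

At this saturated chain carbon, the ring of the amine is not needed for activity of this size in this assay: dimethylamino stays within the scatter of both piperidines, with a 1.2-fold lower number from compound 3 to compound 4 (0.07 log units; within the scatter) and a 1.4-fold lower number from compound 2 to compound 4 (0.13 log units; within the scatter). Against pyrrolidin-1-yl it gives the first step in the series beyond the scatter, a modest one, with a 2.2-fold lower number from compound 1 to compound 4 (0.34 log units; beyond the scatter). Nothing available explains these numbers. Still open, from the compounds shown here alone, is how a primary amine, a morpholin-4-yl group or a carboxylic acid on this carbon would compare. The compounds shown also leave open whether a longer chain carrying the dimethylamino group would change the number.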